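Cyclohexenyl for Thiophenyl at the Distal Ring of Compound 3

This account rests on a few compounds, and the source may have more. Where it says the series, first, only, none or still open, it means among the compounds named here.

Compounds measured so far:
compound 1, `CCC(C)CNCCN(C(=O)[C@@H]1C[C@H]1c1ccccc1)c1ccc(-c2ccccc2)cc1`, 4.7 nM in a functional assay for agonist activity at G protein-coupled receptor 88 (Homo sapiens), read by HTRF and cAMP accumulation; a higher number here means that more compound is needed for the effect, a lower number that less compound is needed;
compound 2, `CC[C@H](C)[C@H](N)CN(C(=O)[C@@H]1C[C@H]1c1nc(C)c(C)s1)c1ccc(-c2ccccc2)cc1`, 3600 nM in this assay;
compound 3, `CC(C)C[C@H](N)CN(C(=O)[C@@H]1C[C@H]1c1ccccc1)c1ccc(-c2ccsc2)cc1`, 1200 nM in this assay.

Compound 3 stands second highest of the three numbers in this assay. Its nearest neighbour is compound 2, whose number is higher by a gap that lies beyond the scatter, while compound 1 lies far lower, by a gap also well beyond the scatter. For the measured compounds named here, no pair among the three differs in one place only, so no single step can be read from them; compound 1 and compound 3 differ both in the amine side chain and in the distal ring.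

Compound 4, `CC(C)C[C@H](N)CN(C(=O)[C@@H]1C[C@H]1c1ccccc1)c1ccc(C2=CCCCC2)cc1`, is compound 3 with one change: cyclohex-1-en-1-yl in place of thiophen-3-yl on an aromatic carbon. Nothing measured here isolates the effect of that ring. The swap trades one ring for another of similar size, with no change in charge, so a modest shift is expected in this assay, if anything towards a somewhat higher number, and a step no larger than a 1.3-fold higher number from compound 3 to compound 4 (0.10 log units; within the scatter) is estimated. Compound 4 is therefore expected to give about 1500 nM in this assay, within a range of 400 nM to 6000 nM.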

Compound 4, half-maximal effective concentration: 1200 nM
The estimate for compound 4 lay 1.3-fold (0.10 log units) above the measured number, and the stated range covers the measured number.
By their numbers in this assay, from the lowest: compound 1; then compounds 3 and 4 (each within the scatter of the next); then compound 2.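

For the compounds shown here, the step from thiophen-3-yl to cyclohex-1-en-1-yl is the first single-place comparison in this set, and at this position, on an aromatic carbon para to a large group, it gives no change at the digits printed from compound 3 to compound 4 (within the scatter) in this assay. The earlier compounds shown here could not show this, since each pair among them differs in more than one place. Here a five-membered aromatic ring holding a sulfur atom and counted with one hydrogen-bond acceptor gives way to a six-membered non-aromatic ring of carbon only, with one double bond and no such acceptor, and for this pair the number stays within the scatter; no available evidence bears on why the two rings read alike.

From the compounds shown here alone, whether this holds on the amine side chain of compound 1, whose number lies far lower, remains open, as compound 1 differs from compound 3 and compound 4 in more than the distal ring. Also open, going by these compounds, is how other groups at this position would read in this assay, such as a saturated cyclohexyl ring, a pyridin-3-yl ring or a carboxylic acid.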